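A few compounds are considered here, and "the series" means these few. Any claim that something is new, unique, unknown or untested is made for them only; others in the source may bear on it.

Working notes on the series. Compound 1 `CCCCCCCCCCCCCCNC(=O)C(CO[C@@H]1O[C@H](CO)[C@H](O)[C@H](O)[C@H]1O)NC(=O)CCC(=O)NCCS(=O)(=O)O` has been tested in a functional assay on MT4 cells (Homo sapiens) for cytotoxicity; on this read-out lower numbers stand for higher toxicity in this test and higher numbers for lower toxicity in this test. In this read-out compound 1 gives > 100000 nM, which is a limit of the assay and not a number. Compound 2 `NC(CO[C@@H]1O[C@H](CO)[C@H](O)[C@H](O)[C@H]1O)C(=O)NCCCCCCCCCCCC(=O)O` has likewise been run in this assay. There compound 2 gives > 100000 nM, again a limit rather than a number. Within the data shown here, compound 1 therefore stands where every value so far stands, namely at the limit of > 100000 nM in this assay, at which 2 of the 2 values shown sit. Among the measured compounds shown here, with both measured compounds sitting at the same limit, no step between measured compounds can be written down, and nothing in the numbers separates compound 1 from compound 2.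

The next compound to go into this assay is compound 3 `CCCCCCCCCCCCCCNC(=O)C(CO[C@@H]1O[C@H](CO)[C@H](O)[C@H](O)[C@H]1O)NC(=O)CCCCCCCCCCC(=O)O`. Its difference from compound 1 is 8-carboxyoctyl in place of (2-sulfoethyl)carbamoyl on a saturated chain carbon, two bonds along the chain from a carbonyl carbon. The shared core of compound 1 is otherwise kept.

Given that compound 1 and compound 2 both sit at the limit of > 100000 nM in this assay, at which 2 of the 2 values shown sit, the step from compound 1 to compound 3 is expected to be none beyond the scatter, and the reading is expected most likely to end once more at a limit. The expected step is a step that the limit leaves unreadable from compound 1 to compound 3. For compound 3 the estimated value is 150000 nM, within 60000 nM and 400000 nM.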

Compound 3, half-maximal cytotoxic concentration: > 100000 nM
Compound 3 gave a limit, no number; the forecaster's own chance of this, stated with the estimate: 85%; the middle value does not contradict the limit.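

Among these compounds, compound 3, like compound 1, gives only a limit and not a number, so no step from compound 1 to compound 3 can be read, whether for 8-carboxyoctyl or for (2-sulfoethyl)carbamoyl: the limit of > 100000 nM in this assay, at which 3 of the 3 values shown sit. The compounds shown leave open whether any change to this series would give a measurable number in this assay.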